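A Furan in Place of a Substituted Phenyl Ring

A few compounds are considered here, and "the series" means these few. Any claim that something is new, unique, unknown or untested is made for them only; others in the source may bear on it.

Measured compounds:
compound 1 `Nc1nc(-c2ccc(CO)cc2)nc2sc(-c3ccccc3)nc12`: > 30000 nM
compound 2 `COc1ccc(-c2nc(N)c3nc(-c4ccccc4)sc3n2)cc1`: > 30000 nM

In a functional assay on CHO cells for antagonist activity at adenosine receptor A2b (Homo sapiens), read by cAMP accumulation, with a stated time of 10 min (on this read-out lower numbers stand for stronger inhibition and higher numbers for weaker inhibition), compound 1 reaches only a limit of the assay, > 30000 nM. Compound 2 likewise gives only a limit, > 30000 nM. The change from compound 1 to compound 2 is methoxy in place of hydroxymethyl on an aromatic carbon, and its step is a step that the two limits leave unreadable from compound 1 to compound 2, because of the limit of > 30000 nM in this assay, at which 2 of the 2 values shown sit. So compound 1 stands at the edge of what this assay reports, and nothing among the measured pairs places it more precisely.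

Compound 3 `Nc1nc(-c2ccco2)nc2sc(-c3ccccc3)nc12` differs from compound 1 by furan-2-yl in place of 4-(hydroxymethyl)phenyl on an aromatic carbon. Among the measured compounds shown here, no measured step touches this exchange, and the one measured step is itself unreadable, so no direction can be drawn from it. The estimate for compound 3 therefore rests on the shared core, which in compound 1 gave only a limit: compound 3 is expected to sit near that same region, a step of a number no higher from compound 1 to compound 3 (the limit leaves the size open), with an estimated value of 30000 nM in a range from 3000 nM to 100000 nM.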

Compound 3, half-maximal inhibitory concentration: > 30000 nM
Compound 3: a limit, no number (the forecaster's own chance of this, stated with the estimate: 60%); the middle value sits exactly at the limit.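

In this assay compound 3 gives > 30000 nM, again a limit and not a number. The steps to compound 3 from compound 1 and compound 2 cannot be read, because all rest on the same edge: the limit of > 30000 nM in this assay, at which 3 of the 3 values shown sit.

The compounds shown leave open whether exchanging 4-(hydroxymethyl)phenyl, 4-methoxyphenyl and furan-2-yl changes inhibition at all.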